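Clearance notes on the step to compound 3

This account rests on a few compounds, and the source may have more. Where it says the series, first, only, none or still open, it means among the compounds named here.

In an ADME assay on microsomes from liver (Mus musculus, strain CD1) for metabolic stability, read by HPLC, using NADPH, with a stated time of 30 min, tested at 0.5 uM (on this read-out higher numbers stand for fast clearance and lower numbers for slow clearance), compound 1 (`Cc1ccc(-c2cc(C(=O)Nc3cccnc3)c3cc(F)ccc3n2)cc1`) gives 8.6 mL.min-1.g-1 and compound 2 (`O=C(NCCN1CCCC1)c1cc(-c2ccc(S(=O)(=O)N3CCOCC3)cc2)nc2ccc(F)cc12`) gives 1.9 mL.min-1.g-1 as the lower of the two numbers, with a gap beyond the usual scatter. Compound 3 (`O=C(NCCN1CCCC1)c1cc(-c2ccc(CN3CCCC3=O)cc2)nc2ccc(F)cc12`) keeps the rest of compound 2 and carries (2-oxopyrrolidin-1-yl)methyl in place of (morpholin-4-yl)sulfonyl on an aromatic carbon. Among the measured compounds shown here, no measured pair differs in one place, so the expectation rests on compound 2 at 1.9 mL.min-1.g-1 alone. In this assay the expected step of a 1.6-fold higher number from compound 2 to compound 3 (0.20 log units; within the scatter) is a small rise that stays within the scatter. For compound 3 the estimated value is 3 mL.min-1.g-1 with an expected range from 1.5 mL.min-1.g-1 to 7 mL.min-1.g-1 on this read-out.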

Compound 3, intrinsic clearance in microsomes in the Mus musculus assay: 2 mL.min-1.g-1
Beside the measured number, compound 3's estimate is 1.5-fold (0.18 log units) above it, within the range that was stated.
By their numbers in the Mus musculus assay, from the lowest: compounds 2 and 3 (each within the scatter of the next); then compound 1.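

In the Mus musculus assay, the (2-oxopyrrolidin-1-yl)methyl group in place of (morpholin-4-yl)sulfonyl on an aromatic carbon, para to a large group, gives a 1.1-fold higher number from compound 2 to compound 3 (0.02 log units; within the scatter), so clearance does not separate these two groups. In a physicochemical assay for solubility, read by nephelometry, measured as kinetic solubility (a lower number here means a less soluble compound, a higher number a more soluble compound), the same change gives an at least 1.9-fold higher number from compound 2 to compound 3 (0.29 log units; that floor lies within the scatter). In the physicochemical assay compound 2 gives 109000 nM. In the physicochemical assay compound 3 gives > 217000 nM as a limit, not a number: the limit of > 217000 nM in the physicochemical assay, at which 1 of the 2 values shown sits.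

Still open, as far as these compounds go, is how an amine, a carboxylic acid or a longer chain at this place reads for clearance and solubility. From the compounds shown here alone, the solubility of compound 3 beyond its limit also remains open.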